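This account rests on a few compounds, and the source may have more. Where it says the series, first, only, none or still open, it means among the compounds named here.

Compound 2 `O=C(O)c1cccc(C2=C(c3cc(Cl)ccc3OCc3ccccc3)CCC2)c1` carries a chloro group on one aromatic ring and, in an assay on isolated protein for inhibition of prostaglandin E2 receptor EP1 subtype (Homo sapiens) (a lower number here means a stronger inhibitor, a higher number a weaker inhibitor), gives 5.01 nM, the lowest of the three numbers recorded. Compound 1 `O=C(O)c1cncc(C2=C(c3cc(C(F)(F)F)ccc3OCc3ccccc3)CCC2)c1` gives 10 nM in this assay, which lies within the scatter of compound 2 and so cannot be ordered against it. For the measured compounds named here, compound 3 `O=C(O)c1cccc(C2=C(c3cc(Br)ccc3OCc3ccccc3)CCC2)c1` gives 12.6 nM, and the only single-point step among the measured compounds, a 2.5-fold higher number from compound 2 to compound 3 (0.40 log units; beyond the scatter), shows a modest weakening on exchanging chloro for bromo.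

The step to compound 4 `O=C(O)c1cc(C2=C(c3cc(Cl)ccc3OCc3ccccc3)CCC2)cnn1` is a different kind of change: 6-carboxypyridazin-4-yl in place of 3-carboxyphenyl on a double-bonded ring carbon. Going by the values given here, no measured pair differs in exactly this way. Among the compounds with values here, the only bearing comes from compound 1, whose aromatic ring with one nitrogen atom sits alongside a trifluoromethyl group rather than chloro, so its two values with compound 2 cannot be attributed to the ring alone; they differ by an amount that is within the scatter. Inserting two ring nitrogens is a larger change than that, and the estimate allows for a modest loss. Compound 4 is therefore expected to give roughly 15 nM in this assay, with a range from 4 nM to 60 nM. The expected step, a 3.0-fold higher number from compound 2 to compound 4 (0.48 log units; beyond the scatter), is a moderate weakening, though the data leave it uncertain whether it will clear the scatter at all.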

Compound 4, half-maximal inhibitory concentration: 39.8 nM
Estimate against measurement, compound 4: 2.7-fold (0.42 log units) below, within the range that was stated.
By their numbers in this assay, from the lowest: compounds 2, 1 and 3 (each within the scatter of the next, the first and the last beyond it); then compound 4.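

Within this assay, the exchange of 3-carboxyphenyl for 6-carboxypyridazin-4-yl on a double-bonded ring carbon gives a 7.9-fold higher number from compound 2 to compound 4 (0.90 log units; beyond the scatter), showing that this position responds to a change in the ring that carries the acid, whereas the only earlier single-point step, a 2.5-fold higher number from compound 2 to compound 3 (0.40 log units; beyond the scatter), concerned the halogen. The exchange leaves the count of 9 heavy atoms and the 1 hydrogen-bond donor unchanged; the counted differences are the 2 ring nitrogens and 3 hydrogen-bond acceptors in place of 1, so the weakening goes with a change confined to the ring itself. The data shown offer no measurement that explains the weakening.

The compounds shown leave open whether both ring nitrogens contribute to the step, since they enter together and compound 1, with its one ring nitrogen, also differs from compound 2 in carrying trifluoromethyl rather than chloro. They also leave open how this position would respond if an amide or a tetrazole stood in place of the carboxylic acid on either ring.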